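The source may report more compounds than this note shows. Statements on the series, on what has been measured and on what is new or still open speak of the compounds shown alone.

Working notes on the step to compound 4, read in a functional assay on HCT-116 cells (Homo sapiens) for inhibition, read by MTT assay, with a stated time of 48 h; a lower number here means a stronger inhibitor, a higher number a weaker inhibitor. Compound 3 `COc1ccc(-n2c(SCC(=O)c3ccc(OC)c(O)c3)nnc2-c2cc(OC)c(OC)c(OC)c2)cc1` gives > 60000 nM in this assay, and this is a limit of the assay and not a number. Compound 1 `COc1ccc(CSc2nnc(-c3cc(OC)c(OC)c(OC)c3)n2-c2ccc(OC)cc2)cc1` gives 49600 nM, and compound 2 `COc1ccc(-n2c(SCc3ccc(F)cc3)nnc2-c2cc(OC)c(OC)c(OC)c2)cc1` gives 38700 nM. Compound 4 `COc1ccc(-n2c(SCC(=O)c3ccc4ccccc4c3)nnc2-c2cc(OC)c(OC)c(OC)c2)cc1` carries naphthalen-2-yl in place of 3-hydroxy-4-methoxyphenyl on a carbonyl carbon. Within the data shown here, no measured step makes this exchange. The nearest steps change the group on the saturated chain carbon bound to a sulfur: an at least 1.2-fold higher number from compound 1 to compound 3 (0.08 log units; that floor lies within the scatter) and an at least 1.5-fold higher number from compound 2 to compound 3 (0.19 log units; that floor lies within the scatter). The remaining step is a 1.3-fold lower number from compound 1 to compound 2 (0.11 log units; within the scatter). None of the three points to a large effect, so compound 4 is expected to read close to compound 1 at 49600 nM and compound 2 at 38700 nM. An estimated step of an at least 1.5-fold lower number from compound 3 to compound 4 (0.17 log units; that floor lies within the scatter) is expected, toward a lower number but not beyond the scatter. For compound 4 the expected value is 40000 nM, with an estimated range of 15000 nM to 75000 nM.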

Compound 4, half-maximal inhibitory concentration: > 60000 nM
Compound 4 was reported as a limit; the forecaster's own chance of this, stated with the estimate: 35%; at least 1.5-fold (0.17 log units) between middle value and limit.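

In this assay compound 4 gives > 60000 nM, which is a limit of the assay and not a number. Compound 3 sits at the same limit, so the step between the two cannot be read, and replacing 3-hydroxy-4-methoxyphenyl with naphthalen-2-yl on the carbonyl carbon, which removes the hydrogen-bond donor and both acceptors of that group, yields no reading below the limit: the limit of > 60000 nM in this assay, at which 2 of the 4 values shown sit. Against the compounds lacking the carbonyl, the steps are an at least 1.5-fold higher number from compound 2 to compound 4 (0.19 log units; that floor lies within the scatter) and an at least 1.2-fold higher number from compound 1 to compound 4 (0.08 log units; that floor lies within the scatter), so neither floor separates compound 4 from them.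

Going by these compounds, whether an amine or a carboxylic acid on the aromatic ring bound to the carbonyl would bring a reading below the limit remains open. Also open, on these data alone, is how far past the limit compound 3 and compound 4 lie, and so whether they differ at all.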